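Methyl on the piperidine ring of a shared aminobenzothiazole core

The source may report more compounds than this note shows. Statements on the series, on what has been measured and on what is new or still open speak of the compounds shown alone.

Three compounds share one core and were measured in a functional assay on A549 cells (Homo sapiens) for cytotoxicity, read by WST assay, with a stated time of 72 h; on this read-out higher numbers stand for weaker inhibition and lower numbers for stronger inhibition. Compound 1 `COc1cc2c(Nc3nc4ccc(C(=O)Nc5c(C)cccc5Cl)cc4s3)ncnc2cc1OCCCN1CCCCC1C` gives 6700 nM. Compound 2 `CCN(CC)CCCOc1cc2ncnc(Nc3nc4ccc(C(=O)Nc5c(C)cccc5C)cc4s3)c2cc1OC` reaches only the limit of the assay, > 100000 nM, not a number. Compound 3 `COc1cc2c(Nc3nc4ccc(C(=O)Nc5c(C)cccc5C)cc4s3)ncnc2cc1OCCCN1CCCCC1` likewise stops at the limit, > 100000 nM. For the measured compounds named here, the only measured step, a step that the two limits leave unreadable from compound 2 to compound 3, cannot be read, because the limit of > 100000 nM in this assay, at which 2 of the 3 values shown sit, hides any difference between them. Compound 3 therefore stands at the weak end of what this assay can report.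

Compound 4 `COc1cc2c(Nc3nc4ccc(C(=O)Nc5c(C)cccc5C)cc4s3)ncnc2cc1OCCCN1CCCCC1C` differs from compound 3 by methyl in place of hydrogen on a saturated ring carbon. Going by the values given here, no measured step covers this change, so the evidence is thin. Compound 1 carries that same methyl on the ring and gives 6700 nM, though it also differs elsewhere, on the ring attached to the amide. Compound 4 is estimated at 40000 nM, between 8000 nM and 200000 nM. The expected step of an at least 2.5-fold lower number from compound 3 to compound 4 (0.39 log units; beyond the scatter) is therefore a guess toward stronger inhibition, and the result may again be only a limit.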

Compound 4, half-maximal inhibitory concentration: 75700 nM
Compound 4: middle estimate off by 1.9-fold (0.28 log units), on the low side, within the range that was stated.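

In this assay, 2-methylpiperidin-1-yl gives a measured number on a core where piperidin-1-yl and diethylamino give only limits, and the piece records an at least 1.3-fold lower number from compound 3 to compound 4 (0.12 log units; that floor lies within the scatter) and an at least 1.3-fold lower number from compound 2 to compound 4 (0.12 log units; that floor lies within the scatter) as the two steps to that number. Each of these steps is only a floor that lies within the scatter, so the size of the change cannot be read, because compounds 2 and 3 sit at a limit: the limit of > 100000 nM in this assay, at which 2 of the 4 values shown sit. For the compounds shown here, the one step of readable size lies elsewhere, at the aromatic carbon, where methyl in place of chloro gives an 11-fold higher number from compound 1 to compound 4 (1.05 log units; beyond the scatter) with the 2-methylpiperidin-1-yl group held the same.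

How much the ring methyl adds in the presence of chloro remains open, as that chloro compound with plain piperidin-1-yl is not among those shown. Also open, going by these compounds, is whether ethyl on that ring carbon, or bromo in place of the chloro, would move the number further.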